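A few compounds are considered here, and "the series" means these few. Any claim that something is new, unique, unknown or untested is made for them only; others in the source may bear on it.

Compound 1 `CNC1=CC(=O)c2c(cnc(C)c2C)C1=O` and compound 2 `CNC1=CC(=O)c2cc(C)ncc2C1=O` share one core. In a functional assay on MEXF 462NL cells (Homo sapiens) for cytotoxicity, read by propidium iodide staining, with a stated time of 4 days (a lower number here means a stronger inhibitor, a higher number a weaker inhibitor), compound 1 gives 49900 nM and compound 2 gives 19000 nM. The step of a 2.6-fold lower number from compound 1 to compound 2 (0.42 log units; beyond the scatter) went with hydrogen in place of methyl on an aromatic carbon. Compound 2 holds the lower of these two numbers. Compound 3 `Cc1cc2c(cn1)C(=O)C(NCl)=CC2=O` differs from compound 2 by chloro in place of methyl on an amine nitrogen. Going by the values given here, no measured step touches the amine nitrogen, so the single step seen bears only loosely; in this assay a step of at most modest size, in either direction, is expected. Compound 3 is estimated at 15000 nM, within 5000 nM to 50000 nM. A step of a 1.3-fold lower number from compound 2 to compound 3 (0.10 log units; within the scatter) is thus expected.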

Compound 3, half-maximal inhibitory concentration: 5640 nM
Compound 3: the middle estimate sits 2.7-fold (0.42 log units) above what was measured; the measured number falls inside the stated range.
By their numbers in this assay, from the lowest: compound 3; then compound 2; then compound 1.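

Going by these compounds alone, the amine nitrogen, which no earlier step touched, also affects the number: in this assay, chloro in place of methyl there gives a 3.4-fold lower number from compound 2 to compound 3 (0.53 log units; beyond the scatter). This is a modest step, and it swaps one heavy atom for one heavy atom with no change in the counted hydrogen-bond donors, acceptors or net charge. Nothing available explains why the number moves. From the compounds shown here alone, whether an ethyl group, a longer chain, or bromo on this nitrogen would move the number further remains open. So does whether the change on the aromatic carbon would act the same way with chloro present.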